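Benzylic sulfonamide-amide series: aryl amide replacement

The source may hold more compounds than are shown below. What is called first, only, known or untested is meant among the compounds shown, and "the series" means these compounds.

Measured so far:
compound 1 `O=C(NCc1ccc(CNS(=O)(=O)c2ccccc2)cc1)c1ccc([N+](=O)[O-])cc1` 100 nM
compound 2 `Cc1ccc(S(=O)(=O)NCc2ccc(CNC(=O)c3c(Cl)cc(Cl)cc3Cl)cc2)cc1` 10 nM
compound 3 `O=C(NCc1ccc(CNS(=O)(=O)c2ccccc2)cc1)c1ccncc1` 10 nM

In an assay on MDA-MB-231 cells for binding affinity to C-X-C chemokine receptor type 4 (Homo sapiens), read by immunofluorescence and microscopy, with stated times of 10 min and 30 min (on this read-out lower numbers stand for an effect already at smaller amounts and higher numbers for an effect only at larger amounts of compound), compound 3 stands level with compound 2 at the digits given; the two together give the lowest numbers of the three. Going by the values given here, compound 1 sits at the high end: the step of a 10-fold lower number from compound 1 to compound 3 (1.00 log units; beyond the scatter) is the only step at this place that is measured, and it is the only change at the carbonyl carbon that has a measured step.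

Compound 4 `O=C(NCc1ccc(CNS(=O)(=O)c2ccccc2)cc1)c1c(Cl)cc(Cl)cc1Cl` is not yet measured. It differs from compound 3 as follows: 2,4,6-trichlorophenyl in place of pyridin-4-yl on a carbonyl carbon. Among the compounds with values here, no measured step covers this exact change. Within the data shown here, what bears on it is the value of compound 2, which carries the same 2,4,6-trichlorophenyl on the carbonyl carbon and in this assay gives 10 nM; compound 2 and compound 4 differ elsewhere, in the ring on the sulfonyl group, and no step is measured for that pair.

On that basis compound 4 is expected to stay within the scatter of compound 3, a step of no change at the digits printed from compound 3 to compound 4 (within the scatter) and no change beyond the scatter. The estimate for compound 4 in this assay is 10 nM, with a range from 4 nM to 30 nM.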

Compound 4, effective concentration (reported as EC, without a stated level of effect): 10 nM
The estimate for compound 4 equals the measured number at the digits printed; measured number inside the range.
By their numbers in this assay, from the lowest: compounds 2, 3 and 4 (each within the scatter of the next); then compound 1.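

In this assay the carbonyl carbon tolerates two very different rings, with no change at the digits printed from compound 3 to compound 4 (within the scatter) on exchanging pyridin-4-yl for 2,4,6-trichlorophenyl, so the ring nitrogen of pyridin-4-yl is not needed to hold this level among the compounds shown. 4-Nitrophenyl now stands apart from two groups rather than one, as the step of a 10-fold lower number from compound 1 to compound 4 (1.00 log units; beyond the scatter) joins the earlier 10-fold lower number from compound 1 to compound 3 (1.00 log units; beyond the scatter) at the same place. The first measured step away from the carbonyl carbon, hydrogen in place of methyl on an aromatic carbon, gives no change at the digits printed from compound 2 to compound 4 (within the scatter) and leaves the number where it was.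

Going by these compounds, whether a ring bearing an amine or a carboxylic acid, or a saturated cyclohexyl group, would hold this level on the carbonyl carbon stays open. No supporting evidence accompanies these results to account for them.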